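Adding a substituted ring to compound 3

This account rests on a few compounds, and the source may have more. Where it says the series, first, only, none or still open, it means among the compounds named here.

In a functional assay for inhibition, with Homo sapiens as the target (a lower number here means tighter binding, a higher number weaker binding), compound 1 `N#Cc1ccccc1C1OCC(C/C=C\CCC(=O)O)C(c2cccnc2)O1` gives 245 nM as its value, compound 2 `O=C(O)CC/C=C\CC1COC(c2ccsc2)OC1c1cccnc1` gives 1580 nM as its value, and compound 3 `CC(C)(Oc1ccccc1)C1OCC(C/C=C\CCC(=O)O)C(c2cccnc2)O1` gives 75.9 nM as its value, the lowest number of the three. Compound 4 `Cc1ccc(C#N)c(OC(C)(C)C2OCC(C/C=C\CCC(=O)O)C(c3cccnc3)O2)c1` is still unmeasured. It differs from compound 3 by 2-cyano-5-methylphenyl in place of phenyl on an oxygen on a saturated carbon with 2-cyano-5-methylphenyl in place of phenyl on an oxygen on a saturated carbon.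

Among the measured compounds shown here, no measured step touches that phenyl, so the evidence is indirect. Swapping the whole group on the saturated ring carbon gave a 3.2-fold lower number from compound 1 to compound 3 (0.51 log units; beyond the scatter) and also a 21-fold lower number from compound 2 to compound 3 (1.32 log units; beyond the scatter) in the same test, so changes in this part of the molecule have moved the number by modest to large amounts. The nearest hint concerns the nitrile-bearing ring of compound 1, where thiophen-3-yl in place of 2-cyanophenyl gave a 6.4-fold higher number from compound 1 to compound 2 (0.81 log units; beyond the scatter) as a modest rise. That is a single comparison, not a rule. The expected outcome is therefore a modest move to a lower number, with the estimated step being a 3.0-fold lower number from compound 3 to compound 4 (0.48 log units; beyond the scatter) in this assay as a tentative call. For compound 4 the estimated value is 25 nM with an expected range from 6 nM to 100 nM.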

Compound 4, dissociation constant: 15.9 nM
Compound 4: middle estimate off by 1.6-fold (0.20 log units), on the high side, and the stated range covers the measured number.
By their numbers in this assay, from the lowest: compound 4; then compound 3; then compound 1; then compound 2.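

Among the compounds shown here, compound 4 gives the first direct reading on the phenyl on an oxygen on a saturated carbon: 2-cyano-5-methylphenyl in place of phenyl gives a 4.8-fold lower number from compound 3 to compound 4 (0.68 log units; beyond the scatter) in this assay, so this outer ring can move the number by itself, and earlier steps showed this only for the whole group on the saturated ring carbon. The change brings in a nitrile and a methyl together, so the step belongs to the pair and cannot be divided between them. A nitrile-bearing ring also sits on the lower-number side of the step between compound 1 and compound 2, but that ring stands at a different place in the molecule, and two such cases make no rule, while nothing measured here accounts for the drop.

The compounds shown leave open how much of the step comes from the nitrile and how much from the methyl, since neither group appears alone on this ring. They also leave open whether another group on the ring, such as a methoxy, a chlorine or an amine, would give a lower or a higher number than the nitrile does.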